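The source may hold more compounds than are shown below. What is called first, only, known or untested is meant among the compounds shown, and "the series" means these compounds.

Measured in a functional assay on DU-145 cells (Homo sapiens) for inhibition, read by trypan blue exclusion, with a stated time of 96 h; on this read-out higher numbers stand for weaker inhibition of growth and lower numbers for stronger inhibition of growth:
- compound 1 `Cc1ccc(/C=C(\C(=O)c2ccc([N+](=O)[O-])cc2)S(=O)(=O)Cc2ccc(Cl)cc2)s1`: 25000 nM
- compound 2 `Cc1ccc(CS(=O)(=O)/C(=C/c2cccc(Cl)c2Cl)C(=O)c2ccc(Cl)cc2)cc1`: 1000 nM
- compound 3 `O=C(/C(=C\c1ccccc1OCc1ccccc1)SCc1ccc(Cl)c(Cl)c1)c1ccc(Cl)cc1`: 10000 nM

Compound 1 has the highest number of the three, and so the weakest growth inhibition in this assay. Both gaps, to compound 3 and to compound 2, lie beyond the scatter.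

The next compound, compound 4 `COc1cc(OC)c(/C=C(\C(=O)c2ccc([N+](=O)[O-])cc2)S(=O)(=O)Cc2ccc(Cl)cc2)c(OC)c1`, keeps the rest of compound 1 and puts 2,4,6-trimethoxyphenyl in place of 5-methylthiophen-2-yl on a double-bonded chain carbon bound to a double-bonded chain carbon.

Among the measured compounds shown here, the measured compounds differ from each other in more than one place, so no clean step calibrates this change. Compound 2, which also has a six-membered aromatic ring of carbon only at this place, gives 1000 nM. Compound 3 also has such a ring but gives only 10000 nM, so the support is weak. A clear step towards stronger inhibition is expected, with a wide margin. The expected change is a 17-fold lower number from compound 1 to compound 4 (1.22 log units; beyond the scatter). For compound 4 the estimate is 1500 nM, with an expected range from 200 nM to 10000 nM.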

Compound 4, concentration for 50% growth inhibition: 10000 nM
Estimate against measurement, compound 4: 6.7-fold (0.82 log units) below; low and high end bracket the measured number.
By their numbers in this assay, from the lowest: compound 2; then compounds 3 and 4 (each within the scatter of the next); then compound 1.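

In this assay, among the compounds shown here, the only clean step at this place, on a double-bonded chain carbon bound to a double-bonded chain carbon, is a 2.5-fold lower number from compound 1 to compound 4 (0.40 log units; beyond the scatter) and counts as modest. With the rest of compound 1 held, the position does respond to the group it carries, but 2,4,6-trimethoxyphenyl in place of 5-methylthiophen-2-yl moves growth inhibition only by this modest amount. No measurement at hand explains the size of this step.

Still open, from the compounds shown here alone, is how a plain phenyl or a pyridin-2-yl at this place would compare with 2,4,6-trimethoxyphenyl and with 5-methylthiophen-2-yl. Also open, going by these compounds, is whether the same exchange gives a step of similar size on a core other than that of compound 1.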